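A few compounds are considered here, and "the series" means these few. Any claim that something is new, unique, unknown or untested is made for them only; others in the source may bear on it.

Measured so far in an assay on isolated protein (urine) for inhibition of Myeloperoxidase (Homo sapiens), with a stated time of 5 min; on this read-out higher numbers stand for weaker inhibition and lower numbers for stronger inhibition:
compound 1, `N#CCCCc1c[nH]c2ccc(F)cc12`: 63 nM
compound 2, `NC(=O)CCc1c[nH]c2c(F)cccc12`: 271 nM

Compound 1 stands lowest of the two numbers in hand; in this assay compound 1 gives 63 nM. Compound 2 gives 271 nM in this assay, a higher number, and the gap between the two is beyond the usual scatter. The two structures differ in more than one place, so nothing beyond the two values themselves is to be read from that gap.

The step followed here runs from compound 1 to compound 3, `CCSCCc1c[nH]c2ccc(F)cc12`, which has not yet been measured in this assay. (ethylsulfanyl in place of cyanomethyl on a saturated chain carbon, two bonds along the chain from an aromatic carbon). The triple bond is lost in the exchange, and the shared core and its fluorine are untouched.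

Going by the values given here, no step between measured compounds stands as a guide for a change of this kind, so the expectation rests on compound 1 alone. The step from compound 1 to compound 3 is estimated as a 1.9-fold higher number from compound 1 to compound 3 (0.28 log units; within the scatter), a small move toward a higher number, close to the scatter. Compound 3 is therefore expected to give about 120 nM in this assay, with a range from 40 nM to 400 nM.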

Compound 3, half-maximal inhibitory concentration: > 100 nM
Compound 3: only a limit was reported; the forecaster's own chance of this, stated with the estimate: 2%; the middle value does not contradict the limit.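

Compound 3 carries only a limit in this assay, > 100 nM, and this is not a number. Read against compound 1, the exchange of cyanomethyl for ethylsulfanyl on a saturated chain carbon, two bonds along the chain from an aromatic carbon, gives an at least 1.5-fold higher number from compound 1 to compound 3 (0.20 log units; that floor lies within the scatter), so this first one-place change in the series fixes only a floor for the step, and the true size may lie within the scatter or well beyond it. The pair therefore cannot settle whether the nitrile with its triple bond matters at this chain end, or whether ethylsulfanyl serves there about as well, and the reading itself sets that bound: the limit of > 100 nM in this assay, at which 1 of the 3 values shown sits.

Still open, going by these compounds, are the actual number behind the limit for compound 3 and the effect of other groups at this chain end, such as an amine, a carboxylic acid or a longer chain ending in the nitrile. The amide of compound 2 gives no guide here, since it differs from compound 1 in more than one place, and the contribution of the fluorine on the shared core also remains unresolved.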